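The compounds below may be only part of what the source reports. "The series", "measured", "known", "first", "only" and "open" are said of these compounds alone.

Measured compounds:
compound 1 `CN1CCc2nc(C#Cc3cccc(Cl)c3)ccc2C1=O` — 250 nM
compound 2 `Cc1cccc(C#Cc2ccc3c(n2)CCN(C(C)C)C3=O)c1` — 510 nM
compound 3 `CC(C)N1CCc2nc(C#Cc3ccccc3Cl)ccc2C1=O` — 5680 nM

In an assay on HEK293 cells for displacement of a labelled ligand from metabotropic glutamate receptor 5 (Homo sapiens), with a stated time of 2 h (a higher number here means a weaker inhibitor, a lower number a stronger inhibitor), compound 3 gives the highest number of the three, with compound 2 nearest and compound 1 furthest. Compound 4 `CC(C)N1CCc2nc(C#Cc3cccc(Cl)c3)ccc2C1=O` carries 3-chlorophenyl in place of 2-chlorophenyl on a triple-bonded carbon. For the measured compounds named here, no measured step covers exactly this exchange. Going by the values given here, the one step that bears on the group on the triple-bonded carbon is an 11-fold higher number from compound 2 to compound 3 (1.05 log units; beyond the scatter), a large loss on going to the 2-chlorophenyl. Compound 1, which also carries a 3-chlorophenyl but with a different group on the amide nitrogen, gives 250 nM, close to compound 2. Compound 4 is therefore expected to fall well below compound 3, by about a 14-fold lower number from compound 3 to compound 4 (1.15 log units; beyond the scatter). The estimated value of compound 4 in this assay is 400 nM, within a range of 150 nM to 1100 nM.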

Compound 4, inhibition constant: 100 nM
Beside the measured number, compound 4's estimate is 4.0-fold (0.60 log units) above it; the measured number lies below the stated range.
By their numbers in this assay, from the lowest: compound 4; then compound 1; then compound 2; then compound 3.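

In this assay, 3-chlorophenyl in place of 2-chlorophenyl on the triple-bonded carbon gives a 57-fold lower number from compound 3 to compound 4 (1.75 log units; beyond the scatter) and so shows that, with the same atoms in the group, the place of the chlorine alone carries a large change. Chloro in place of methyl on the aromatic carbon gives a 5.1-fold lower number from compound 2 to compound 4 (0.71 log units; beyond the scatter) and isopropyl in place of methyl on the amide-type nitrogen gives a 2.5-fold lower number from compound 1 to compound 4 (0.40 log units; beyond the scatter) so both of these exchanges are modest by comparison. Nothing available accounts for these differences.

Still open, from the compounds shown here alone, is how a fluorophenyl or a methoxyphenyl on the triple-bonded carbon would compare with the 3-chlorophenyl. Also open, going by these compounds, is whether a longer chain on the amide-type nitrogen would continue the gain seen with isopropyl.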